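Methoxy in Place of Bromo on the Sulfonyl Aryl Ring

The source may report more compounds than this note shows. Statements on the series, on what has been measured and on what is new or still open speak of the compounds shown alone.

Compound 1, `CN(c1ccc2[nH]c(-c3n[nH]c4ccccc34)cc2n1)S(=O)(=O)c1ccccc1`, gives 12000 nM in a functional assay on SMMC-7721 cells (Homo sapiens) for antiproliferative activity, read by MTT assay, with a stated time of 72 h; on this read-out lower numbers stand for stronger inhibition and higher numbers for weaker inhibition. Compound 2, `Cc1ccc(S(=O)(=O)N(C)c2ccc3[nH]c(-c4n[nH]c5ccccc45)cc3n2)cc1`, gives 16300 nM. Compound 3, `CN(c1ccc2[nH]c(-c3n[nH]c4ccccc34)cc2n1)S(=O)(=O)c1ccc(Br)cc1`, gives 11500 nM.

Compound 3 has the lowest of the three numbers, yet its gap to compound 1 and to compound 2 is within the scatter, so none of the three can be set apart from the others. The measured steps that change the same aromatic carbon all stayed flat: a 1.0-fold lower number from compound 1 to compound 3 (0.02 log units; within the scatter), a 1.4-fold lower number from compound 2 to compound 3 (0.15 log units; within the scatter), and a 1.4-fold higher number from compound 1 to compound 2 (0.13 log units; within the scatter). Compound 4, `COc1ccc(S(=O)(=O)N(C)c2ccc3[nH]c(-c4n[nH]c5ccccc45)cc3n2)cc1`, differs from compound 3 by methoxy in place of bromo on an aromatic carbon. Every substitution tried so far at this carbon has left the read-out unchanged within the scatter, so the expectation for the step from bromo to methoxy is no shift beyond the scatter, in either direction. The step expected from compound 3 to compound 4 is therefore a 1.1-fold higher number from compound 3 to compound 4 (0.04 log units; within the scatter). On that basis compound 4 is estimated at 12500 nM, with a range from 5000 nM to 32000 nM.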

Compound 4, half-maximal inhibitory concentration: 13000 nM
Beside the measured number, compound 4's estimate is 1.0-fold (0.02 log units) below it; the measured number falls inside the stated range.
By their numbers in this assay, from the lowest: compounds 3, 1, 4 and 2 (each within the scatter of the next).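

Going by these compounds alone, the methoxy group is the first group at this carbon that brings an oxygen and a hydrogen-bond acceptor, and in this assay the step is still within the scatter: a 1.1-fold higher number from compound 3 to compound 4 (0.05 log units; within the scatter) and a 1.3-fold lower number from compound 2 to compound 4 (0.10 log units; within the scatter) and a 1.1-fold higher number from compound 1 to compound 4 (0.03 log units; within the scatter) are all that it gives. Hydrogen, methyl, bromo and methoxy therefore cannot be told apart here, so on the 4-methoxyphenyl compound too an added acceptor leaves the read-out where it was, and no pattern can be drawn among the four compounds. Nothing available here accounts for this flat result.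

These compounds leave open whether an amine or a carboxylic acid at this carbon would carry the number beyond the scatter. They also leave open whether a change elsewhere on the shared core would move it at all.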